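The source may hold more compounds than are shown below. What is called first, only, known or untested is meant among the compounds shown, and "the series" means these compounds.

Of the compounds shown here, three sharing one core have been tested in an ADME assay on HEK293 cells (Homo sapiens) for cytotoxicity, with a stated time of 72 h; on this read-out higher numbers stand for an effect only at larger amounts of compound and lower numbers for an effect already at smaller amounts. Compound 1, `C=C[C@@](C)(/C=C/c1ccc(O)cc1)CC/C=C(C)/C=N/N`, gives > 36600 nM, which is a limit of the assay and not a number. Compound 2, `C=C[C@@](C)(/C=C/c1ccc(O)cc1)CC/C=C(\C)CO`, gives > 36600 nM, again a limit. Compound 3, `C=C[C@@](C)(/C=C/c1ccc(O)cc1)CC/C=C(C)/C=C/C(=O)OCC`, gives > 36600 nM, also a limit. Compound 3 therefore has no number of its own and stands with the other two, as the limit of > 36600 nM in this assay, at which 3 of the 3 values shown sit, shows.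

Compound 4, `C=C[C@@](C)(/C=C/c1ccc(O)cc1)CC/C=C(C)/C=C/C(=O)OCc1ccccc1`, differs from compound 3 in its ester: phenyl in place of methyl on a saturated chain carbon bound to an oxygen next to a carbonyl group, which reads as ethoxycarbonyl to benzyloxycarbonyl (phenyl in place of methyl on a saturated chain carbon bound to an oxygen next to a carbonyl group). The measured steps bear on this change only loosely. They are a step that the two limits leave unreadable from compound 1 to compound 2, a step that the two limits leave unreadable from compound 1 to compound 3 and a step that the two limits leave unreadable from compound 2 to compound 3, and each swaps the whole group on a double-bonded chain carbon, so none has a readable size. They give no direction for the new change, and no step beyond the scatter is expected in this assay. Compound 4 is expected to remain near the same limit, on the strength of the limit of > 36600 nM in this assay, at which 3 of the 3 values shown sit, and may well be reported only as a limit. The expected step is a step that the limit leaves unreadable from compound 3 to compound 4. For compound 4 the estimated value is 38000 nM, with an expected range from 15000 nM to 80000 nM.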

Compound 4, half-maximal effective concentration: > 36600 nM
Compound 4: a limit, no number (the forecaster's own chance of this, stated with the estimate: 75%); the middle value does not contradict the limit.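

In this assay compound 4 gives > 36600 nM, which is a limit of the assay and not a number. Compound 3 also stands at a limit, so no step can be read between compound 3 and compound 4. The compounds shown leave open whether any of them affects these cells, and at what amount, because all stand at one limit: the limit of > 36600 nM in this assay, at which 4 of the 4 values shown sit.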